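The compounds below may be only part of what the source reports. "The series", "measured", "known", "first", "only" and "open" are said of these compounds alone.

Measured compounds, permeability:
- compound 1 `c1ccc(-c2ccc3c(NCCCNCc4ccco4)ccnc3c2)cc1`: 237 10^-6 cm/s
- compound 2 `COc1ccc(Oc2ccc3c(NCCCNCc4ccco4)ccnc3c2)cc1`: 317 10^-6 cm/s
- compound 3 `c1ccc(CCc2ccc3c(NCCCNCc4ccco4)ccnc3c2)cc1`: 23 10^-6 cm/s

In an ADME assay for permeability, using PAMPA, with a stated time of 30 min, at pH 7.4 (a lower number here means that the compound crosses the layer more slowly, a higher number that the compound crosses the layer faster), compound 3 stands lowest of the three numbers: the steps of a 10-fold lower number from compound 1 to compound 3 (1.01 log units; beyond the scatter) and a 14-fold lower number from compound 2 to compound 3 (1.14 log units; beyond the scatter) are both beyond the scatter, while a 1.3-fold higher number from compound 1 to compound 2 (0.13 log units; within the scatter) stays within it. Compound 4 `COc1cccc(Oc2ccc3c(NCCCNCc4ccco4)ccnc3c2)c1` is the next compound; the change from compound 3 is 3-methoxyphenoxy in place of phenethyl on an aromatic carbon. The step of a 14-fold lower number from compound 2 to compound 3 (1.14 log units; beyond the scatter) bears most directly on it, as compound 4 carries 3-methoxyphenoxy where compound 2 carries 4-methoxyphenoxy, and the step of a 1.3-fold higher number from compound 1 to compound 2 (0.13 log units; within the scatter) shows the two aryl ether and aryl variants close together. A large rise is therefore expected for compound 4, a 12-fold higher number from compound 3 to compound 4 (1.09 log units; beyond the scatter). The estimate for compound 4 is 280 10^-6 cm/s, range 150 10^-6 cm/s to 450 10^-6 cm/s.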

Compound 4, apparent permeability: 317 10^-6 cm/s
Compound 4: the middle estimate sits 1.1-fold (0.05 log units) below what was measured; the range from low to high includes it.
By their numbers in this assay, from the lowest: compound 3; then compounds 1, 2 and 4 (each within the scatter of the next).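

In this assay, among these compounds, 3-methoxyphenyl in place of 4-methoxyphenyl on the oxygen gives no change at the digits printed from compound 2 to compound 4 (within the scatter) and is the first read on where the methoxy group sits in the aryl ether. Compound 3 remains the lone low member, with a 14-fold higher number from compound 3 to compound 4 (1.14 log units; beyond the scatter), while a 1.3-fold higher number from compound 1 to compound 4 (0.13 log units; within the scatter) keeps this second aryl ether level with the phenyl compound. Nothing available accounts for the gap to phenethyl. As far as these compounds go, whether an amine or a carboxylic acid in place of the methoxy group would hold the aryl ether at this level stays open, as does the behaviour of unsubstituted phenoxy.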